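Fluoro to methyl on the outer ring of compound 3

A few compounds are considered here, and "the series" means these few. Any claim that something is new, unique, unknown or untested is made for them only; others in the source may bear on it.

Of the compounds shown here, three have numbers so far. In a functional assay (Cavia porcellus) with sulfonylurea receptors; K-ATP channels (Homo sapiens) as the target (on this read-out higher numbers stand for weaker inhibition and lower numbers for stronger inhibition), compound 1 `COc1cc(NC(=O)C(C)(O)C(F)(F)F)ccc1S(=O)(=O)c1ccccc1` gives 5900 nM, compound 2 `CC(O)(C(=O)Nc1ccc(S(=O)(=O)c2ccccc2Cl)cc1)C(F)(F)F` gives 2300 nM, and compound 3 `CC(O)(C(=O)Nc1ccc(C(=O)c2cccc(F)c2)cc1)C(F)(F)F` gives 2600 nM. Among these three, compound 3 stands second highest. Its nearest neighbour is compound 2, whose number lies within the scatter of that of compound 3, so no order between the two can be read. Compound 1 lies beyond the scatter, with a higher number than compound 3, and is the furthest of the set from it.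

Compound 4 `Cc1cccc(C(=O)c2ccc(NC(=O)C(C)(O)C(F)(F)F)cc2)c1` is not yet measured. It differs from compound 3 in one place: methyl in place of fluoro on an aromatic carbon. Read one bond further out, 3-fluorophenyl becomes 3-methylphenyl, on the ring that sits meta to a large group. Within the data shown here, no pair of measured compounds differs in exactly this way, so no measured step can be carried over.

Given that, the step from compound 3 to compound 4 is expected to be small, no change at the digits printed from compound 3 to compound 4 (within the scatter), and not beyond the scatter in either direction. For compound 4 in this assay the estimate is 2600 nM, with a range from 1000 nM to 6500 nM.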

Compound 4, half-maximal inhibitory concentration: > 30000 nM
Compound 4: no number, only a limit; the forecaster's own chance of this, stated with the estimate: 10%; middle value at least 11-fold (1.06 log units) away from the limit.
By their numbers in this assay, from the lowest: compounds 2 and 3 (each within the scatter of the next); then compound 1. At a limit, above all of these: compound 4.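

In this assay compound 4 gives > 30000 nM, which is a limit of the assay and not a number. Among these compounds, the change from 3-fluorophenyl to 3-methylphenyl swaps one heavy atom for one heavy atom, with no ring, hydrogen-bond donor, hydrogen-bond acceptor or net charge entering or leaving, yet it carries an at least 11-fold higher number from compound 3 to compound 4 (1.06 log units; beyond the scatter); this place on the outer ring is therefore far from indifferent to what it holds, which the earlier compounds, with no pair among them differing in one place, could not show. Compound 4 is alone at this limit in the set: the limit of > 30000 nM in this assay, at which 1 of the 4 values shown sits.

With fluoro and methyl as the only groups shown at this place, the compounds do not tell whether the drop in inhibition is specific to methyl or would also follow from other groups there, such as an amine or a nitrile. Whether the same change would have a comparable effect on the core of compound 1 or compound 2 also stays open, as the step is shown on the core of compound 3 alone.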